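A few compounds are considered here, and "the series" means these few. Any claim that something is new, unique, unknown or untested is made for them only; others in the source may bear on it.

Among the measured compounds shown here, compound 2 `COc1ccc(-c2cn(-c3cccc(C(=O)/C=C/c4ccc(O)c(OC)c4)c3)c(=O)[nH]2)cc1` is the one compound of this series for which a number has been reported in a functional assay on EKVX cells (Homo sapiens) for inhibition; a lower number here means a stronger inhibitor of growth, a higher number a weaker inhibitor of growth: compound 2 gives 13400 nM, and it therefore stands alone as the reference point. Compound 1 `COc1cc(/C=C/C(=O)c2cccc(-n3cc(-c4ccc(Cl)cc4)[nH]c3=O)c2)cc(OC)c1OC`, which carries a 3,4,5-trimethoxyphenyl and a 4-chlorophenyl, is recorded in this assay as "not active" (no number reported), without a number. Compound 3 `COc1ccc(-c2cn(-c3cccc(C(=O)/C=C/c4cc(OC)c(OC)c(OC)c4)c3)c(=O)[nH]2)cc1` has not yet been measured. It differs from compound 2 in one respect: 3,4,5-trimethoxyphenyl in place of 4-hydroxy-3-methoxyphenyl on a double-bonded chain carbon bound to a double-bonded chain carbon. For the measured compounds named here, since no measured pair shows this exact change, the size of the step has to be judged from what compound 1 shows. The step from compound 2 to compound 3 is expected to weaken growth inhibition, by a 2.6-fold higher number from compound 2 to compound 3 (0.42 log units; beyond the scatter), beyond the usual scatter. Given that compound 1 gives "not active" (no number reported) in this assay, compound 3 is expected to come in at about 35000 nM, within a range of 10000 nM to 120000 nM.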

Compound 3, concentration for 50% growth inhibition: 4200 nM
Beside the measured number, compound 3's estimate is 8.3-fold (0.92 log units) above it; measured number below the stated range.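

In this assay the change to 3,4,5-trimethoxyphenyl on a double-bonded chain carbon bound to a double-bonded chain carbon gives a 3.2-fold lower number from compound 2 to compound 3 (0.50 log units; beyond the scatter) and so strengthens growth inhibition, which shows that this position responds to the change and that the hydrogen-bond donor of 4-hydroxy-3-methoxyphenyl is not required for activity in this pair. The group does not secure a number by itself: with the same 3,4,5-trimethoxyphenyl and a 4-chlorophenyl in place of the 4-methoxyphenyl of compound 3, compound 1 is recorded as "not active" (no number reported) in this assay. Nothing measured here explains the step.

The pair leaves open whether the gain follows the loss of the hydroxyl or the gain of a methoxy group. A 3,4-dimethoxyphenyl, or an amine or carboxylic acid on this ring, would bear on that question.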